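Capping the piperazin-1-yl group with cyclopropylmethyl

The source may report more compounds than this note shows. Statements on the series, on what has been measured and on what is new or still open speak of the compounds shown alone.

Of the compounds shown here, two have been measured so far in a physicochemical assay for solubility, read by HPLC, using the shake flask method, in phosphate buffer, measured as kinetic solubility, with a stated time of 20 h, at pH 6.5; on this read-out lower numbers stand for lower solubility and higher numbers for higher solubility. In that read-out, compound 1 (`Fc1ccc(Nc2cc3[nH]c(Nc4ccc(N5CCN(CC6CC6)CC5)cn4)nc3cn2)cc1C(F)(F)F`) gives 75000 nM. Compound 2 (`Fc1ccc(Nc2cc3[nH]c(Nc4ccc(N5CCNCC5)cn4)nc3cn2)cc1F`) gives < 5000 nM, and this is a limit of the assay and not a number.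

Compound 3 (`Fc1ccc(Nc2cc3[nH]c(Nc4ccc(N5CCN(CC6CC6)CC5)cn4)nc3cn2)cc1F`) is still unmeasured. It differs from compound 2 in one place: cyclopropylmethyl in place of hydrogen on an amine nitrogen in a ring. In words, cyclopropylmethyl stands in place of hydrogen on an amine nitrogen in a ring, turning piperazin-1-yl into 4-(cyclopropylmethyl)piperazin-1-yl.

Within the data shown here, no pair of measured compounds shows this change on its own, so any forecast remains loose. The expectation rests on compound 1, which also bears 4-(cyclopropylmethyl)piperazin-1-yl and gives 75000 nM in this assay. An upward move is therefore expected, well beyond the usual scatter, and the estimated size is an at least 8.0-fold higher number from compound 2 to compound 3 (0.90 log units; beyond the scatter). For compound 3 the estimated value is 40000 nM, with an expected range from 8000 nM to 150000 nM.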

Compound 3, solubility: 10000 nM
For compound 3 the middle estimate is 4.0-fold (0.60 log units) above the measured one; the range from low to high includes it.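

Among these compounds, on the amine nitrogen in the ring, this assay now gives a first step for cyclopropylmethyl in place of hydrogen: an at least 2.0-fold higher number from compound 2 to compound 3 (0.30 log units; that floor lies within the scatter). Compound 2 remains a limit of the assay and not a number, so only a floor is known for this step, and that floor does not clear the scatter; the limit in question is: the limit of < 5000 nM in this assay, at which 1 of the 3 values shown sits. With 4-(cyclopropylmethyl)piperazin-1-yl held fixed, fluoro in place of trifluoromethyl on an aromatic carbon gives a 7.5-fold lower number from compound 1 to compound 3 (0.88 log units; beyond the scatter), so the high reading of compound 1 does not belong to the cyclopropylmethyl group alone.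

The true size of the step on the ring nitrogen stays open, and so does whether it would hold with trifluoromethyl on the aromatic carbon, since the compounds shown include no trifluoromethyl partner with hydrogen on that nitrogen. Also open, as far as these compounds go, is how other groups on that nitrogen, such as methyl, acetyl or a longer chain, and other groups on the aromatic carbon, such as chloro or nitrile, would read in this assay.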